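The source may hold more compounds than are shown below. What is called first, only, known or untested is meant among the compounds shown, and "the series" means these compounds.

Of the compounds shown here, three on the shared core have been read in a physicochemical assay for solubility, read by spectrophotometry, in phosphate buffer, with a stated time of 18 h, at pH 7.4; a lower number here means a less soluble compound, a higher number a more soluble compound. Compound 1 (`Cc1ccc(-c2nc3c(c(C)nn3-c3ccccc3)c(-c3ccccc3O)c2C#N)cc1`) gives 26000 nM, compound 2 (`Cc1ccccc1-c1nc2c(c(C)nn2-c2ccccc2)c(-c2ccccc2O)c1C#N`) gives 21000 nM, and compound 3 (`Cc1nn(-c2ccccc2)c2nc(-c3ccc(F)cc3)c(C#N)c(-c3ccccc3O)c12`) gives 6000 nM, the lowest of the three numbers, with both gaps to it beyond the scatter. Compound 4 (`Cc1nn(-c2ccccc2)c2nc(-c3ccc(Cl)cc3)c(C#N)c(-c3ccccc3O)c12`) is not yet measured. It differs from compound 3 by chloro in place of fluoro on an aromatic carbon, para to a large group.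

The nearest evidence is a 4.3-fold lower number from compound 1 to compound 3 (0.64 log units; beyond the scatter), a modest step with fluoro in place of methyl on an aromatic carbon. Of similar size is a 3.5-fold lower number from compound 2 to compound 3 (0.54 log units; beyond the scatter), with 4-fluorophenyl in place of 2-methylphenyl, while a 1.2-fold lower number from compound 1 to compound 2 (0.09 log units; within the scatter) stays within the scatter. Among the measured compounds shown here, no measured compound carries chloro, so the data do not fix a direction. A step no larger than these modest ones is expected, probably none beyond the scatter. The estimated step is a 1.2-fold lower number from compound 3 to compound 4 (0.08 log units; within the scatter). For compound 4 the estimated solubility is 5000 nM, with an expected range of 1500 nM to 17000 nM.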

Compound 4, solubility: 3800 nM
For compound 4 the middle estimate is 1.3-fold (0.12 log units) above the measured one; the range from low to high includes it.
By their numbers in this assay, from the lowest: compounds 4 and 3 (each within the scatter of the next); then compounds 2 and 1 (each within the scatter of the next).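

In this assay the two halogens on this aromatic carbon, para to a large group, are not separated: chloro in place of fluoro gives a 1.6-fold lower number from compound 3 to compound 4 (0.20 log units; within the scatter) and stays within the scatter. Chloro in place of methyl gives a larger step (a 6.8-fold lower number from compound 1 to compound 4 (0.84 log units; beyond the scatter)), and 4-chlorophenyl in place of 2-methylphenyl gives a 5.5-fold lower number from compound 2 to compound 4 (0.74 log units; beyond the scatter), so among these four compounds both halogen compounds sit apart from both methyl compounds, with no compound going against this. Nothing measured here bears on the reason for that split.

Going by these compounds, whether the split extends beyond halogen and methyl remains open, as an amine or a carboxylic acid on this carbon would be a different kind of test. The nitrile and the rest of the shared core stay fixed throughout, so their contribution is also unresolved.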